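A methyl added to the phenyl ring of compound 2

The compounds below may be only part of what the source reports. "The series", "measured", "known", "first", "only" and "open" are said of these compounds alone.

Compound 2 `CCN(CC)CN1C(=O)/C(=N/NC(=S)Nc2ccccc2)c2ccccc21` gives 800 nM in an ADME assay on MDCK cells (Canis lupus familiaris) for cytotoxicity (a lower number here means that less compound is tolerated, a higher number that more compound is tolerated), the lower of the two numbers recorded. Compound 1 `CCN(CC)CN1C(=O)/C(=N/NC(N)=S)c2ccccc21` gives 100000 nM. Among the compounds with values here, the single measured step is a 130-fold lower number from compound 1 to compound 2 (2.10 log units; beyond the scatter). Compound 3 `CCN(CC)CN1C(=O)/C(=N/NC(=S)Nc2ccc(C)cc2)c2ccccc21` differs from compound 2 in one place: methyl in place of hydrogen on an aromatic carbon. That measured step bears only loosely on this change, since it concerns a whole ring rather than a methyl, and no other comparison exists. Compound 3 is therefore expected to give 600 nM, between 200 nM and 2500 nM. The expected step is a 1.3-fold lower number from compound 2 to compound 3 (0.12 log units; within the scatter), not beyond the scatter.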

Compound 3, minimum cytotoxic concentration: 800 nM
Compound 3: middle estimate off by 1.3-fold (0.12 log units), on the low side, within the range that was stated.
By their numbers in this assay, from the lowest: compounds 2 and 3 (each within the scatter of the next); then compound 1.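

In this assay there is no change at the digits printed from compound 2 to compound 3 (within the scatter) when a methyl replaces hydrogen on the aromatic carbon para to a large group, so this position takes a methyl with no change beyond the scatter. The large step from the unsubstituted thiourea nitrogen also persists with the new ring, with a 130-fold lower number from compound 1 to compound 3 (2.10 log units; beyond the scatter) on going to 4-methylphenyl. No evidence here accounts for either result. From the compounds shown here alone, whether a methoxy, a carboxylic acid or an amine at this position would also leave the number unchanged remains open.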